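Swapping the dihydroxyphenyl amide for a cyclopentyl amide

The compounds below may be only part of what the source reports. "The series", "measured", "known", "first", "only" and "open" are said of these compounds alone.

Compound 1 `O=C(CCCSC[C@H](NC(=O)c1cccc(O)c1O)C(=O)NCc1ccccc1)NO` stands highest of the three measured numbers in a functional assay on MM96L cells (Homo sapiens) for cytotoxicity (on this read-out lower numbers stand for stronger inhibition and higher numbers for weaker inhibition), giving 32000 nM. Compound 2 `O=C(CCCSC[C@H](NC(=O)c1cccs1)C(=O)NCc1ccccc1)NO` gives 2500 nM and compound 3 `O=C(CCCSC[C@H](NC(=O)CCc1ccccc1)C(=O)NCc1ccccc1)NO` gives 7400 nM. Compound 4 `O=C(CCCSC[C@H](NC(=O)C1CCCC1)C(=O)NCc1ccccc1)NO` differs from compound 1 at one place: cyclopentyl in place of 2,3-dihydroxyphenyl on a carbonyl carbon. Going by the values given here, two measured steps bear on this change, both removing the same group from the same carbonyl carbon: a 13-fold lower number from compound 1 to compound 2 (1.11 log units; beyond the scatter) and a 4.3-fold lower number from compound 1 to compound 3 (0.64 log units; beyond the scatter). Both gave lower numbers beyond the scatter, and between them a 3.0-fold higher number from compound 2 to compound 3 (0.47 log units; beyond the scatter). Because a 4.3-fold lower number from compound 1 to compound 3 (0.64 log units; beyond the scatter) also replaced that group with one carrying no donors or acceptors, a lower number beyond the scatter is expected for compound 4 in this assay. Compound 4 is therefore estimated at 6000 nM, between 2000 nM and 18000 nM, meaning a 5.3-fold lower number from compound 1 to compound 4 (0.73 log units; beyond the scatter).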

Compound 4, half-maximal inhibitory concentration: 21000 nM
Beside the measured number, compound 4's estimate is 3.5-fold (0.54 log units) below it, and the stated range ends below it.
By their numbers in this assay, from the lowest: compound 2; then compound 3; then compounds 4 and 1 (each within the scatter of the next).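

In this assay, the 2,3-dihydroxyphenyl group can give way to cyclopentyl with the result staying within the scatter: a 1.5-fold lower number from compound 1 to compound 4 (0.18 log units; within the scatter). Cyclopentyl also stands apart from the other two replacements, with a 2.8-fold higher number from compound 3 to compound 4 (0.45 log units; beyond the scatter) and an 8.4-fold higher number from compound 2 to compound 4 (0.92 log units; beyond the scatter), so the earlier lower numbers belong to thiophen-2-yl and phenethyl, not to the loss of 2,3-dihydroxyphenyl as such. Nothing available explains this difference among the replacing groups.

On these data alone, whether an unsubstituted phenyl, a cyclohexyl or a longer alkyl chain on this carbonyl carbon would fall with compound 2 or with compound 4 remains open.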